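This account rests on a few compounds, and the source may have more. Where it says the series, first, only, none or still open, it means among the compounds named here.

Of the compounds shown here, three built on one shared core have been measured in a functional assay on DLD-1 cells (Homo sapiens) for antiproliferative activity, read by CellTiter-Glo, with a stated time of 72 h; a higher number here means a weaker inhibitor, a lower number a stronger inhibitor. Compound 1 `CC1CCN(C2CCN(S(=O)(=O)c3ccc(-c4ccccc4)cc3)CC2)CC1` gives 258 nM. Compound 2 `CC1CCN(C2CCN(S(=O)(=O)c3ccc(OC(F)(F)F)cc3)CC2)CC1` gives 16 nM. Compound 3 `CCCCOc1ccc(S(=O)(=O)N2CCC(N3CCC(C)CC3)CC2)cc1` gives 2300 nM, the highest of the three numbers: its nearest neighbour is compound 1, and the step of an 8.9-fold higher number from compound 1 to compound 3 (0.95 log units; beyond the scatter) lies beyond the scatter, while the step of a 140-fold higher number from compound 2 to compound 3 (2.16 log units; beyond the scatter) is larger still. Compound 4 `COC(=O)c1ccc(S(=O)(=O)N2CCC(N3CCC(C)CC3)CC2)cc1` has not yet been measured. It differs from compound 3 in one place: methoxycarbonyl in place of butoxy on an aromatic carbon. Among the measured compounds shown here, no measured step introduces methoxycarbonyl, so none bears on this change directly. What the measured steps do show is that butoxy sits at the weak end of this small set: a 16-fold lower number from compound 1 to compound 2 (1.21 log units; beyond the scatter) and an 8.9-fold higher number from compound 1 to compound 3 (0.95 log units; beyond the scatter) put phenyl and trifluoromethoxy ahead of butoxy. On that basis compound 4 is expected to move away from the weak end, with a step estimated at a 3.8-fold lower number from compound 3 to compound 4 (0.58 log units; beyond the scatter), and the set gives no measurement with methoxycarbonyl to fix its size. Compound 4 is therefore estimated at 600 nM in this assay, within a range from 120 nM to 3000 nM.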

Compound 4, half-maximal inhibitory concentration: > 5000 nM
Compound 4 ended at the assay's limit; the forecaster's own chance of this, stated with the estimate: 5%; middle value at least 8.3-fold (0.92 log units) from the limit.
By their numbers in this assay, from the lowest: compound 2; then compound 1; then compound 3. At a limit, above all of these: compound 4.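

In this assay compound 4 gives > 5000 nM, which is a limit of the assay and not a number. Even read as a limit, it places methoxycarbonyl behind every other group tried on this aromatic carbon, para to a large group, with an at least 2.1-fold higher number from compound 3 to compound 4 (0.33 log units; beyond the scatter), an at least 19-fold higher number from compound 1 to compound 4 (1.28 log units; beyond the scatter) and an at least 310-fold higher number from compound 2 to compound 4 (2.49 log units; beyond the scatter), so butoxy no longer marks the weak end of the set. The earlier compounds shown here could not show two further points: the smaller methoxycarbonyl does not recover activity relative to butoxy, and the atom joining the group to the ring does not sort the results, since trifluoromethoxy and butoxy both join through oxygen yet lie far apart, as do phenyl and methoxycarbonyl, which both join through carbon.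

The compounds shown leave open how far compound 4 lies past the limit, so the true size of all three steps remains unknown. They also leave open whether a carboxylic acid or an amide at this position would sit as far from compound 2, and whether a trifluoromethyl group would match trifluoromethoxy.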